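Chloro to methyl exchange on the amide series

This account rests on a few compounds, and the source may have more. Where it says the series, first, only, none or still open, it means among the compounds named here.

Values in an assay on Sf9 cells for inhibition of histone-lysine N-methyltransferase EZH2 (Homo sapiens), read by scintillation counting, with a stated time of 60 min, in the presence of a further agent that is not named here; a lower number here means a stronger inhibitor, a higher number a weaker inhibitor:
compound 1 `COc1cccc(C(=O)NCc2c(C)cc(C)[nH]c2=O)c1F`: > 150000 nM.
compound 2 `Cc1cc(C)c(CNC(=O)c2cccc(OC(C)C)c2C)c(=O)[nH]1`: 1400 nM.
compound 3 `COc1cccc(C(=O)NCc2c(C)cc(C)[nH]c2=O)c1Cl`: 7200 nM.

For compound 1 the result is a limit of the assay, > 150000 nM. Of the two actual numbers compound 3 gives the higher one and compound 2 the lower one, a gap beyond the scatter. Within the data shown here, the single measured step at the same place, an at least 20-fold lower number from compound 1 to compound 3 (1.31 log units; beyond the scatter), is large, though it rests on (the limit of > 150000 nM in this assay, at which 1 of the 3 values shown sits). Compound 4, `COc1cccc(C(=O)NCc2c(C)cc(C)[nH]c2=O)c1C`, differs from compound 3 by methyl in place of chloro on an aromatic carbon. Compound 2 carries the same methyl, with isopropoxy in place of methoxy, and gives 1400 nM. A modest improvement, smaller than that gap, is expected for a 2.4-fold lower number from compound 3 to compound 4 (0.38 log units; beyond the scatter). Compound 4 is therefore estimated at 3000 nM, within 800 nM to 12000 nM.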

Compound 4, half-maximal inhibitory concentration: 5700 nM
Compound 4: middle estimate off by 1.9-fold (0.28 log units), on the low side; low and high end bracket the measured number.
By their numbers in this assay, from the lowest: compound 2; then compounds 4 and 3 (each within the scatter of the next). At a limit, above all of these: compound 1.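

In this assay, exchanging chloro for methyl on the aromatic carbon ortho to a methoxy group gives a 1.3-fold lower number from compound 3 to compound 4 (0.10 log units; within the scatter), so the two groups are not told apart at this position. With methyl held there, the oxygen substituent can be read alone, with a 4.1-fold higher number from compound 2 to compound 4 (0.61 log units; beyond the scatter). Fluoro at this position stays apart from both, with an at least 26-fold lower number from compound 1 to compound 4 (1.42 log units; beyond the scatter), but this step rests on a limit for compound 1: the limit of > 150000 nM in this assay, at which 1 of the 4 values shown sits.

Still open, as far as these compounds go, is how bromo, ethyl or trifluoromethyl would read at this position. Also open, from the compounds shown here alone, is whether isopropoxy gives the same step with chloro in place of methyl.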